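Removing One Methoxy Group on Two Related Cores

The source may report more compounds than this note shows. Statements on the series, on what has been measured and on what is new or still open speak of the compounds shown alone.

Compound 1, `COc1cc(-c2cc(/C=C/C(=O)c3ccc(N)cc3)[nH]n2)cc(OC)c1OC`: -13%
Compound 2, `COc1ccc(-c2cc(/C=C/C(=O)c3ccc(N)cc3)[nH]n2)cc1OC`: -5%
Compound 3, `COc1cc(C(=O)/C=C/c2cc(-c3cc(OC)c(OC)c(OC)c3)n[nH]2)cc(OC)c1OC`: 7%

All three compounds were tested in a functional assay on SR cells (Homo sapiens) for cytotoxicity, read by sulforhodamine B assay, with a stated time of 48 h, tested at 100 uM; a lower number here means a stronger effect, a higher number a weaker effect of the compound at the concentration tested. Compound 2 differs from compound 1 by hydrogen in place of methoxy on an aromatic carbon, and this produced a number 8 percentage points higher from compound 1 to compound 2 (within the scatter). Compound 3 is built on a different core; how the core of compound 3 differs from that of compound 1 is not broken down here. In this assay compound 3 stands highest of the three, with compound 2 the nearer of the other two at a lower number beyond the scatter, and compound 1 further below it, also beyond the scatter.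

Compound 4, `COc1ccc(-c2cc(/C=C/C(=O)c3cc(OC)c(OC)c(OC)c3)[nH]n2)cc1OC`, has not yet been measured. It differs from compound 3 by hydrogen in place of methoxy on an aromatic carbon, the same change as that from compound 1 to compound 2, made at a place described in the same words. The expected step is a number 7 percentage points higher from compound 3 to compound 4 (within the scatter), resting on the earlier pair, since compound 2 against compound 1 showed a number 8 percentage points higher from compound 1 to compound 2 (within the scatter). Compound 4 is therefore estimated at 14%, within a range from -2% to 30%.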

Compound 4, a percentage reported as activity, at one concentration (the size of the read-out at that concentration, not a potency): -14%
Compound 4: middle estimate off by 28 percentage points, on the high side; the whole stated range lies above it.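

In this assay, putting hydrogen in place of methoxy on an aromatic carbon gave a number 21 percentage points lower from compound 3 to compound 4 (beyond the scatter). Set beside the earlier pair, this shows that the same change does not give the same step on the two cores, so a step read on the core of compound 1 cannot be carried over to the core of compound 3 in this series: the same change on two cores in this assay, a number 8 percentage points higher (within the scatter) from compound 1 to compound 2 and a number 21 percentage points lower (beyond the scatter) from compound 3 to compound 4, 29 percentage points apart, beyond the scatter of two such steps It does not show why the two cores part ways, and with only one pair on each core and a read-out at a single concentration, it cannot say how the change would behave on any further core.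

The compounds shown vary only in methoxy groups and in the amine that compound 1 and compound 2 carry in place of the methoxy-bearing ring of compound 3 and compound 4. As far as these compounds go, whether a hydroxyl group or a fluorine at the same place would follow either step remains open, as does whether removing a further methoxy group would.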